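Chloro for isopropyl on the shared core

A few compounds are considered here, and "the series" means these few. Any claim that something is new, unique, unknown or untested is made for them only; others in the source may bear on it.

In an ADME assay on LL24 cells (Homo sapiens) for inhibition, read by MTT assay, with a stated time of 24 h (a lower number here means a stronger inhibitor, a higher number a weaker inhibitor), compound 1 `CC(C)c1ccc(C(=O)N/N=C/c2ccc([N+](=O)[O-])o2)cc1` gives > 200000 nM, which is a limit of the assay and not a number. Compound 3 `N#Cc1ccc(C(=O)N/N=C/c2ccc([N+](=O)[O-])o2)cc1` likewise gives > 200000 nM in this assay, again a limit. Compound 2 `CCCCCC(=O)N/N=C/c1ccc([N+](=O)[O-])o1` gives 99000 nM in this assay. Compound 4 `O=C(N/N=C/c1ccc([N+](=O)[O-])o1)c1ccc(Cl)cc1` differs from compound 1 by chloro in place of isopropyl on an aromatic carbon. Among the compounds with values here, the one measured step on the same ring, a step that the two limits leave unreadable from compound 1 to compound 3, gives no readable size because both of its values sit at the limit of > 200000 nM in this assay, at which 2 of the 3 values shown sit. Within the data shown here, no measured step therefore gives a direction for the change, and a reported limit for compound 4 is the most likely outcome. Compound 4 is expected at 200000 nM, with a range of 90000 nM to 450000 nM, which would be a step of a number no higher from compound 1 to compound 4 (the limit leaves the size open).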

Compound 4, half-maximal inhibitory concentration: 187000 nM
Estimate against measurement, compound 4: 1.1-fold (0.03 log units) above; measured number inside the range.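

With chloro on this aromatic carbon, compound 4 gives a number in this assay, the first on this ring, while compound 1 and compound 3 remain limits and not numbers: the limit of > 200000 nM in this assay, at which 2 of the 4 values shown sit.

Chloro in place of isopropyl gives an at least 1.0-fold lower number from compound 1 to compound 4 (0.02 log units; that floor lies within the scatter), and chloro in place of cyano gives an at least 1.0-fold lower number from compound 3 to compound 4 (0.02 log units; that floor lies within the scatter). Both are floors only, so this position shows no order among the three groups.

As far as these compounds go, how far compound 1 and compound 3 truly lie from compound 4 stays open. Also open, from the compounds shown here alone, is whether an amine or a carboxylic acid on this aromatic carbon would give a clearly lower number.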